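Replacing tert-butyl with a larger bicyclic amine substituent

This account rests on a few compounds, and the source may have more. Where it says the series, first, only, none or still open, it means among the compounds named here.

Measured compounds:
compound 1, `CCN(CC)Cc1cc(-c2ccccc2)n(Nc2ccnc3cc(Cl)ccc23)c1C`, 16700 nM
compound 2, `Cc1cc(CNC(C)(C)C)c(C)n1Nc1ccnc2cc(Cl)ccc12`, "not determined" (no result reported)
compound 3, `Cc1c(CNC(C)(C)C)cc(-c2ccccc2)n1Nc1ccnc2cc(Cl)ccc12`, "not determined" (no result reported)

Only compound 1 carries a number in an ADME assay on HMEC-1 cells (Homo sapiens) for cytotoxicity, read by MTT assay (a lower number here means a stronger inhibitor, a higher number a weaker inhibitor), where compound 1 gives 16700 nM. Compound 2 and compound 3 both lack a result in this assay, so compound 3 stands without any number of its own, and the only anchor for the series is the value of compound 1. Compound 4, `Cc1c(CNCC[C@@H]2CCCN3CCCC[C@H]23)cc(-c2ccccc2)n1Nc1ccnc2cc(Cl)ccc12`, is the next member to be measured in this assay. It differs from compound 3 in one place: a group of 12 heavy atoms (11 carbon, 1 nitrogen; 2 six-membered non-aromatic rings with 1 hetero atom each) in place of a group of 4 heavy atoms (4 carbon; no ring), on an amine nitrogen. Among the compounds with values here, with no number for compound 3, no step can be anchored to it, and the size and direction of the change from compound 3 to compound 4 in this assay cannot be read from anything measured here; the expectation rests only on the value of compound 1. Compound 4 is therefore expected to give roughly 10000 nM in this assay, with a range from 2500 nM to 40000 nM.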

Compound 4, half-maximal inhibitory concentration: 14600 nM
For compound 4 the middle estimate is 1.5-fold (0.16 log units) below the measured one, and the stated range covers the measured number.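

With no number shown for compound 3, no step to compound 4 can be read in this assay. Nothing available bears on the value of compound 4. Going by these compounds, what exchanging tert-butyl for the larger bicyclic group does in this assay therefore stays open.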